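Swapping a Ring Group for Methylsulfonyl on the Shared Core

The source may hold more compounds than are shown below. What is called first, only, known or untested is meant among the compounds shown, and "the series" means these compounds.

Measured compounds:
compound 1, `Cc1nc(N2CCN(C3CCCC3)CC2)nc2ccc(NC(=O)COc3ccc(Cl)cc3)cc12`, 150 nM
compound 2, `Cc1nc(N2CCN(C3CCOCC3)CC2)nc2ccc(NC(=O)COc3ccc(Cl)cc3)cc12`, 115 nM

In a functional assay on CHO-K1 cells for antagonist activity at melanin-concentrating hormone receptor 1 (Homo sapiens), read by inositol phosphate accumulation (on this read-out lower numbers stand for stronger inhibition and higher numbers for weaker inhibition), compound 1 gives 150 nM, and compound 2 gives 115 nM. Among the measured compounds shown here, the only step measured so far, a 1.3-fold lower number from compound 1 to compound 2 (0.12 log units; within the scatter), exchanges one ring group for another on the amine nitrogen in a ring and stays within the scatter. Compound 2 thus shows the lowest of the two numbers, but the gap to compound 1 is one the scatter covers, so the two cannot be ordered against each other.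

Compound 3 `Cc1nc(N2CCN(S(C)(=O)=O)CC2)nc2ccc(NC(=O)COc3ccc(Cl)cc3)cc12` alters the same position in a different way: methylsulfonyl in place of oxan-4-yl on an amine nitrogen in a ring. For the measured compounds named here, no measured step bears on this change; the step from compound 1 to compound 2 only shows that one ring group in place of another leaves the number essentially unchanged. A group without a ring now enters. Neither direction nor size of the step can be read from the data. For compound 3 the estimate in this assay is 300 nM, with a range from 80 nM to 1200 nM. The expected step of a 2.6-fold higher number from compound 2 to compound 3 (0.42 log units; beyond the scatter) is accordingly wide in its uncertainty.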

Compound 3, half-maximal inhibitory concentration: > 10000 nM
Compound 3 gave a limit, no number; the forecaster's own chance of this, stated with the estimate: 10%; at least 33-fold (1.52 log units) between middle value and limit.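

Among the compounds shown here, until this result, the amine nitrogen in the ring had carried only ring groups, and exchanging one for the other left the number within the scatter, so nothing yet showed that this position could matter. For compound 3 the outcome in this assay is a limit, not a number: the limit of > 10000 nM in this assay, at which 1 of the 3 values shown sits. Methylsulfonyl in place of oxan-4-yl gives an at least 86-fold higher number from compound 2 to compound 3 (1.93 log units; beyond the scatter), and methylsulfonyl in place of cyclopentyl gives an at least 66-fold higher number from compound 1 to compound 3 (1.82 log units; beyond the scatter), so among these three compounds the group on this nitrogen can make a large difference, even though the two ring groups could not be told apart.

The compounds shown leave open which part of the change counts, since the ring leaves and the sulfonyl enters in the same step. A plain methyl or an acetyl group would test the loss of the ring without a sulfonyl, whereas phenylsulfonyl would keep a ring on the sulfonyl, and the data give no hint of how either would behave.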